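From Propyl Amide to Methyl Urea on the Shared Core

This account rests on a few compounds, and the source may have more. Where it says the series, first, only, none or still open, it means among the compounds named here.

Compound 1 `CCCNC(=O)c1ccc2cc(C(O)(c3c[nH]cn3)C(C)C)ccc2c1` gives 38 nM in an assay on isolated protein for inhibition of steroid 17-alpha-hydroxylase/17,20 lyase (Homo sapiens) (on this read-out higher numbers stand for weaker inhibition and lower numbers for stronger inhibition), the lower of the two numbers recorded so far. Compound 2 `CNC(=O)c1ccc2cc(C(O)(c3c[nH]cn3)C(C)C)ccc2c1C` gives 160 nM in this assay, a higher number that lies beyond the scatter. Compound 3 `CNC(=O)Nc1ccc2cc(C(O)(c3c[nH]cn3)C(C)C)ccc2c1` has not yet been measured; it differs from compound 1 by (methylcarbamoyl)amino in place of propylcarbamoyl on an aromatic carbon. Among the measured compounds shown here, no measured pair isolates this change, so the direction is uncertain; a modest weakening is expected, a 1.8-fold higher number from compound 1 to compound 3 (0.27 log units; within the scatter), within or only just beyond the scatter. Compound 3 is therefore estimated at 70 nM, with a range from 25 nM to 200 nM.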

Compound 3, half-maximal inhibitory concentration: 36 nM
Compound 3: middle estimate off by 1.9-fold (0.29 log units), on the high side, and the stated range covers the measured number.
By their numbers in this assay, from the lowest: compounds 3 and 1 (each within the scatter of the next); then compound 2.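

Replacing propylcarbamoyl with (methylcarbamoyl)amino on this aromatic carbon gives a 1.1-fold lower number from compound 1 to compound 3 (0.02 log units; within the scatter) in this assay, so this read-out does not separate the two groups. Among the compounds shown here, this is the first measured pair that isolates a single change at this position, and it shows that the position accepts the urea-type group with a methyl end as well as the propyl amide. Nothing available bears on the reason for this match. From the compounds shown here alone, how an amine, a carboxylic acid or an ethyl or butyl urea would read at this position remains open.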